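The source may hold more compounds than are shown below. What is called first, only, known or untested is meant among the compounds shown, and "the series" means these compounds.

Measured compounds:
- compound 1, `COc1ccc(N2C(=O)COc3ccc(-c4cnc5ccccc5c4)cc32)cc1`: > 40000 nM
- compound 2, `O=C1COc2ccc(-c3cnc4ccccc4c3)cc2N1c1ccccc1`: > 40000 nM
- compound 3, `O=C1COc2ccc(-c3cnc4ccccc4c3)cc2N1`: 26300 nM

In a functional assay on HepG2 cells (Homo sapiens) for antiproliferative activity, read by MTT assay, with a stated time of 72 h (a higher number here means a weaker inhibitor, a lower number a stronger inhibitor), compound 3 gives 26300 nM, the only number shown among the three. In this assay compound 1 sits at a limit, > 40000 nM. In this assay compound 2 also sits at a limit, > 40000 nM. Compound 4, `O=C1COc2ccc(-c3cnc4ccccc4c3)cc2N1c1ccc(Cl)cc1`, is not yet measured. It differs from compound 3 by 4-chlorophenyl in place of hydrogen on an amide-type nitrogen in a ring.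

Going by the values given here, two measured steps bear on this change, both running the opposite way: the step of an at least 1.5-fold lower number from compound 1 to compound 3 (0.18 log units; that floor lies within the scatter) and the step of an at least 1.5-fold lower number from compound 2 to compound 3 (0.18 log units; that floor lies within the scatter). Each removes an aryl group from the amide-type nitrogen in the ring and each brings the number down from a limit to a readable value, (the limit of > 40000 nM in this assay, at which 2 of the 3 values shown sit). The step that the two limits leave unreadable from compound 1 to compound 2 does not help here. Adding a 4-chlorophenyl at that same nitrogen is therefore expected to push the number up again, most likely back to the limit, as a weaker inhibitor; the expected step is a 1.9-fold higher number from compound 3 to compound 4 (0.28 log units; within the scatter). Compound 4 is therefore expected to give 50000 nM, within a range of 20000 nM to 150000 nM.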

Compound 4, half-maximal inhibitory concentration: 32700 nM
The estimate for compound 4 lay 1.5-fold (0.18 log units) above the measured number, and the stated range covers the measured number.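

Putting 4-chlorophenyl in place of hydrogen on the amide-type nitrogen in the ring gives a 1.2-fold higher number from compound 3 to compound 4 (0.09 log units; within the scatter) in this assay, so an aryl group at this position can still give a readable value, which neither earlier aryl compound had shown. Against the plain phenyl ring, chloro in place of hydrogen on the aromatic carbon gives an at least 1.2-fold lower number from compound 2 to compound 4 (0.08 log units; that floor lies within the scatter), and against the 4-methoxyphenyl ring, chloro in place of methoxy gives an at least 1.2-fold lower number from compound 1 to compound 4 (0.08 log units; that floor lies within the scatter), so neither comparison separates compound 4 from the compound it is set against. Compound 1 and compound 2 each sit at a limit, which leaves only floors for these two steps: the limit of > 40000 nM in this assay, at which 2 of the 4 values shown sit.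

What an amine, a carboxylic acid or a longer alkyl chain would do on this nitrogen remains open, as only hydrogen and aryl rings stand there in the compounds shown. Also open, as far as these compounds go, is whether an amine or a carboxylic acid in place of the chloro on the 4-chlorophenyl ring would move the number beyond the scatter from compound 3.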